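This account rests on a few compounds, and the source may have more. Where it says the series, first, only, none or still open, it means among the compounds named here.

In a functional assay on MCF7 cells (Homo sapiens) for antiproliferative activity (a higher number here means a weaker inhibitor, a lower number a stronger inhibitor), compound 1 (`C=CCc1cc(C(=O)Nc2cc3ccc(OC4CCN(C)CC4)c(C)c3oc2=O)ccc1OC(C)=O`) gives 2000 nM and sits level with compound 2 (`C=CCc1cc(C(=O)Nc2cc3ccc(OC4CCN(C)CC4)c(C)c3oc2=O)ccc1O`) at 2170 nM, while compound 3 (`CC(C)=CCc1cc(C(=O)Nc2cc3ccc(OC4CCN(C)CC4)c(C)c3oc2=O)ccc1OC1CCN(C)CC1`) gives a clearly lower 470 nM. Compound 1 therefore stands in the upper pair of the three numbers. The next change leads to compound 4 (`COc1cccc(-c2cc(C(=O)Nc3cc4ccc(OC5CCN(C)CC5)c(C)c4oc3=O)ccc2OC(C)=O)c1`) and is counted as follows (3-methoxyphenyl in place of allyl on an aromatic carbon). In short, 3-methoxyphenyl replaces allyl on an aromatic carbon, ortho to an acetoxy group.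

Among the compounds with values here, the only measured single-place step is a 1.1-fold higher number from compound 1 to compound 2 (0.04 log units; within the scatter), which exchanges acetyl for hydrogen on an oxygen on an aromatic ring and leaves the allyl untouched. It bears on this change only indirectly. Compound 3 differs from compound 1 in more than one place, so the value of compound 3, 470 nM, cannot be assigned to a single group. Within the data shown here, no measured compound carries the 3-methoxyphenyl, so no clear step is expected in this assay in either direction. The estimated step is a 1.3-fold lower number from compound 1 to compound 4 (0.12 log units; within the scatter), which is expected to stay within the scatter. Compound 4 is expected at 1500 nM within an estimated range of 500 nM to 4500 nM.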

Compound 4, half-maximal inhibitory concentration: 910 nM
Compound 4: middle estimate off by 1.6-fold (0.22 log units), on the high side; low and high end bracket the measured number.
By their numbers in this assay, from the lowest: compounds 3 and 4 (each within the scatter of the next); then compounds 1 and 2 (each within the scatter of the next).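

In this assay, the aromatic carbon ortho to an acetoxy group accepts a 3-methoxyphenyl in place of allyl, and a 2.2-fold lower number from compound 1 to compound 4 (0.34 log units; beyond the scatter) shows that a single change at this position can move the number. The only earlier single-place step, a 1.1-fold higher number from compound 1 to compound 2 (0.04 log units; within the scatter) at the oxygen on the aromatic ring, left the number within the scatter, so among these compounds only the change at this carbon gives a step beyond it. No measurement at hand accounts for this step.

The compounds shown leave open whether the step follows the added aromatic ring or its methoxy group, a question that a plain phenyl at this carbon would address. Also open, on these data alone, is whether the step holds with a hydroxyl in place of the acetoxy group.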